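A Methyl-for-Fluoro Swap Carried Onto a Second Core

This account rests on a few compounds, and the source may have more. Where it says the series, first, only, none or still open, it means among the compounds named here.

Of the compounds shown here, three have so far been measured in an assay on isolated protein for binding affinity to 5-hydroxytryptamine receptor 4 (Homo sapiens); on this read-out lower numbers stand for stronger inhibition and higher numbers for weaker inhibition. Compound 1 `Cc1ccc(-c2n[nH]cc2N2CCCNCC2)cc1` returns only a limit of the assay, > 10000 nM. Compound 2 `Fc1ccc(-c2n[nH]cc2N2CCCNCC2)cc1` likewise returns only a limit, > 10000 nM. Compound 3 `Fc1ccc(-c2n[nH]cc2N2CCNCC2)cc1` also returns only a limit, > 10000 nM.

Compound 2 and compound 1 differ in one place: methyl in place of fluoro on an aromatic carbon. The step this change made is a step that the two limits leave unreadable from compound 2 to compound 1; its size cannot be read because every value shown sits at the limit of > 10000 nM in this assay, at which 3 of the 3 values shown sit. Compound 3 and compound 2 share the same change of methyl against fluoro elsewhere in the series but carry different cores, and the difference between the two cores is not broken down here.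

Compound 4 `Cc1ccc(-c2n[nH]cc2N2CCNCC2)cc1` has not yet been measured in this assay. It differs from compound 3 by methyl in place of fluoro on an aromatic carbon, the same change that leads from compound 2 to compound 1, at a place described in the same words. Going by the values given here, the one earlier instance of this change gave no readable step, and compound 3 itself gives only a limit, so the expectation for compound 4 rests on little more than the three limits already seen. Against that background the step from compound 3 to compound 4 is expected to be a step that the limit leaves unreadable from compound 3 to compound 4. Compound 4 is therefore estimated at 20000 nM, with most of the likelihood that this assay again reports only a limit for compound 4.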

Compound 4, inhibition constant: > 10000 nM
Compound 4: only a limit was reported; the forecaster's own chance of this, stated with the estimate: 85%; the middle value is on the limit's open side.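

In this assay compound 4 gives > 10000 nM, which is a limit of the assay and not a number. No new step can be read between compound 3 and compound 4, because both stand at the same limit, as does every other compound shown: the limit of > 10000 nM in this assay, at which 4 of the 4 values shown sit. The compounds shown leave open how methyl and fluoro compare on either core, and how the two cores compare with each other.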